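Cytotoxicity notes on the shared core, compound 3 outlook

This account rests on a few compounds, and the source may have more. Where it says the series, first, only, none or still open, it means among the compounds named here.

Measured compounds:
Compound 1 `COc1ccc(NC(=O)Nc2cc(C)nc3ccccc23)cc1`: in an ADME assay on HEK293 cells (Homo sapiens) for cytotoxicity, with a stated time of 72 h (on this read-out higher numbers stand for an effect only at larger amounts of compound and lower numbers for an effect already at smaller amounts), compound 1 gives > 25000 nM, a limit of the assay.
Compound 2 `Cc1ccc(NC(=O)Nc2cc(C)nc3ccccc23)cc1`: in this assay compound 2 gives > 25000 nM, a limit of the assay.

Both measured values are limits, not numbers, so the step that the two limits leave unreadable from compound 1 to compound 2 stays unreadable. Compound 2 therefore stands at the limit of > 25000 nM in this assay, at which 2 of the 2 values shown sit, with no measurable value on either side of it; nothing in the measured pair separates compound 2 from compound 1 in this assay.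

Compound 3 `Cc1cc(NC(=O)Nc2ccc(N)cc2)c2ccccc2n1` differs from compound 2 in one place: amino in place of methyl on an aromatic carbon. Among the measured compounds shown here, the only measured step, a step that the two limits leave unreadable from compound 1 to compound 2, bears on a different change and gives no readable size, so no directional case can be built from it. What the data do show is the limit of > 25000 nM in this assay, at which 2 of the 2 values shown sit, and the working expectation is that compound 3 behaves likewise in this assay. Compound 3 is expected to give about 30000 nM, within a range from 12000 nM to 100000 nM. The step that the limit leaves unreadable from compound 2 to compound 3 is thus expected to be none beyond the scatter, most likely reported again only as a limit.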

Compound 3, half-maximal effective concentration: > 25000 nM
Compound 3 gave a limit, no number; the forecaster's own chance of this, stated with the estimate: 80%; the middle value lies beyond the limit too.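

No step among compound 1, compound 2 and compound 3 can be read in this assay, since all three values are limits of the assay, not numbers: the limit of > 25000 nM in this assay, at which 3 of the 3 values shown sit.

The compounds shown leave open how far each compound lies beyond that limit, and whether any group at this aromatic carbon gives a measurable value.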